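The source may hold more compounds than are shown below. What is called first, only, known or untested is meant among the compounds shown, and "the series" means these compounds.

Compound 2, `Nc1scc(CN2CCN(c3ccc(Cl)c(C(F)(F)F)c3)CC2)c1C(=O)c1ccc(Cl)cc1`, stands second highest of the three numbers measured in a functional assay on CHO cells with adenosine receptor A1 (Homo sapiens) as the target, read by cAMP accumulation and immunoassay, with a stated time of 6 min, tested at 0.01 uM; a lower number here means a stronger effect, a higher number a weaker effect of the compound at the concentration tested: compound 2 gives -2.5%. Compound 1, `Nc1scc(CN2CCN(c3ccc(Cl)cc3Cl)CC2)c1C(=O)c1ccc(Cl)cc1`, gives 2% in this assay, and compound 3, `Nc1scc(CN2CCN(c3cccc(F)c3F)CC2)c1C(=O)c1ccc(Cl)cc1`, gives -13%. Compound 4, `Nc1scc(CN2CCN(c3c(F)cc(F)cc3F)CC2)c1C(=O)c1ccc(Cl)cc1`, has not yet been measured. It differs from compound 2 in one place: 2,4,6-trifluorophenyl in place of 4-chloro-3-(trifluoromethyl)phenyl on an amine nitrogen in a ring. Three measured steps change the same aromatic group on the ring nitrogen. The step of a number 4.5 percentage points lower from compound 1 to compound 2 (within the scatter) shows that exchanging one chlorine-bearing ring for another leaves the number essentially unchanged, whereas a number 10.5 percentage points lower from compound 2 to compound 3 (beyond the scatter) and a number 15 percentage points lower from compound 1 to compound 3 (beyond the scatter) show that the ring carrying only fluorine comes with a modestly lower number, beyond the scatter. Compound 4 likewise carries a ring bearing only fluorine, so a modest lowering is expected rather than no change. The step expected for compound 4 is a number 7.5 percentage points lower from compound 2 to compound 4 (within the scatter). For compound 4 the estimated value in this assay is -10%, with a range from -22% to 2%.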

Compound 4, a percentage reported as activity, at one concentration (the size of the read-out at that concentration, not a potency): 4.2%
Estimate against measurement, compound 4: 14.2 percentage points below; the measured number lies above the stated range.
By their numbers in this assay, from the lowest: compound 3; then compounds 2, 1 and 4 (each within the scatter of the next).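

The new result shows that a ring bearing only fluorine on the amine nitrogen in a ring does not by itself bring a lower number in this assay, since a number 6.7 percentage points higher from compound 2 to compound 4 (within the scatter) and a number 2.2 percentage points higher from compound 1 to compound 4 (within the scatter) leave the 2,4,6-trifluorophenyl group indistinguishable from the two chlorine-bearing groups. The two fluorine-only groups instead differ from each other, with a number 17.2 percentage points higher from compound 3 to compound 4 (beyond the scatter), so compound 4 goes against the earlier link between fluorine-only rings and a lower number, and only compound 3 stands apart. Nothing measured here explains this difference between the two fluorine-only groups.

Open, from the compounds shown here alone, is whether the number follows how many fluorines the ring carries or where they sit, as compound 3 and compound 4 differ in both. Also open, going by these compounds, is how an unsubstituted phenyl ring, or a phenyl ring carrying a methoxy group, would read on this nitrogen.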